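From a Carbamate to an Oxadiazole on a Spirocyclic Amine

The source may report more compounds than this note shows. Statements on the series, on what has been measured and on what is new or still open speak of the compounds shown alone.

Compound 1 `CC(C)(C)OC(=O)N1CCC2(CC1)CC(CCCOc1ccc(S(C)(=O)=O)cc1)C2` stands only at a limit: in a physicochemical assay for solubility, read by HPLC, in phosphate buffer, with a stated time of 24 h, at pH 6.8 (a lower number here means a less soluble compound, a higher number a more soluble compound), compound 1 gives < 0.13 ug/mL, which is a limit of the measurement and not a number (the limit of < 0.13 ug/mL in this assay, at which 1 of the 2 values shown sits). Compound 2 `CC1(OC(=O)N2CCC3(CC2)CC(CCCOc2ccc(S(C)(=O)=O)c(F)c2)C3)CC1` likewise reaches only a limit, giving < 0.15 ug/mL in this assay (the limit of < 0.15 ug/mL in this assay, at which 1 of the 2 values shown sits). Compound 3 `CC(C)c1noc(N2CCC3(CC2)CC(CCCOc2ccc(S(C)(=O)=O)cc2)C3)n1` carries 3-isopropyl-1,2,4-oxadiazol-5-yl in place of tert-butoxycarbonyl on an amine nitrogen in a ring. For the measured compounds named here, no step between measured compounds exists to gauge this change. The step is expected to be an at least 3.8-fold higher number from compound 1 to compound 3 (0.58 log units; beyond the scatter), a rise of uncertain size, with a fair chance that only a limit is reported again. Compound 3 is expected to give 0.5 ug/mL in this assay, within 0.1 ug/mL to 3 ug/mL.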

Compound 3, solubility: < 0.13 ug/mL
Compound 3 gave a limit, no number; the forecaster's own chance of this, stated with the estimate: 40%; at least 3.8-fold (0.58 log units) between middle value and limit.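

In this assay, for the compounds shown here, compound 1 and compound 3 both stand only at limits, so no step between them can be read. The compounds shown leave open whether 3-isopropyl-1,2,4-oxadiazol-5-yl and tert-butoxycarbonyl differ at all in this assay on this core.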